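Cyclopropyl for ethyl: cytotoxicity notes on the series

The source may hold more compounds than are shown below. What is called first, only, known or untested is meant among the compounds shown, and "the series" means these compounds.

Compound 1 `CCc1ccc2[nH]c(=O)c(CN(Cc3ccc(C(C)(C)C)cc3)Cc3ccc(F)c(F)c3)cc2c1` gives in a toxicity assay on MDCK cells (Canis lupus familiaris) for cytotoxicity, read by crystal violet staining, with a stated time of 48 h (on this read-out higher numbers stand for lower toxicity in this test and lower numbers for higher toxicity in this test), a value of > 33000 nM, which is a limit.
Compound 2 `CCc1ccc2[nH]c(=O)c(CN(Cc3ccc(C(C)(C)C)cc3)[C@@H](C)c3ccc(OC)cc3)cc2c1` gives in this assay a value of > 5000 nM, again a limit.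
Compound 3 `CCc1ccc2[nH]c(=O)c(CN(Cc3ccc(C(C)(C)C)cc3)C(C)c3ccc(OC(F)F)cc3)cc2c1` gives in this assay a value of > 5000 nM, also a limit.

Compound 2 thus stands only at a limit, shared with compound 3 at the limit of > 5000 nM in this assay, at which 2 of the 3 values shown sit, while compound 1 sits at the limit of > 33000 nM in this assay, at which 1 of the 3 values shown sits. Every measured step is unreadable: a step that the two limits leave unreadable from compound 1 to compound 2, a step that the two limits leave unreadable from compound 1 to compound 3 and a step that the two limits leave unreadable from compound 2 to compound 3. Compound 4 `COc1ccc([C@H](C)N(Cc2ccc(C(C)(C)C)cc2)Cc2cc3cc(C4CC4)ccc3[nH]c2=O)cc1` differs from compound 2 by cyclopropyl in place of ethyl on an aromatic carbon. For the measured compounds named here, no measured step touches that position, so no step beyond the scatter is expected, and a limit is the likely outcome. The expected step that the limit leaves unreadable from compound 2 to compound 4 is essentially flat. Compound 4 is estimated at 10000 nM, within 5000 nM to 33000 nM.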

Compound 4, half-maximal cytotoxic concentration: > 10000 nM
Compound 4 ended at the assay's limit; the forecaster's own chance of this, stated with the estimate: 80%; the middle value sits exactly at the limit.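

The step between compound 2 and compound 4 cannot be read, as both values in this assay are limits. The compounds shown leave open whether cyclopropyl in place of ethyl changes cytotoxicity, and at what concentration any of these compounds becomes toxic.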